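The source may report more compounds than this note shows. Statements on the series, on what has been measured and on what is new or still open speak of the compounds shown alone.

Working notes on the series. In a functional assay on CHO cells for antagonist activity at Glucagon receptor (Homo sapiens), read by cAMP accumulation, with stated times of 30 min and 45 min (on this read-out lower numbers stand for stronger inhibition and higher numbers for weaker inhibition), compound 1 `C[C@H](c1ccc(C(=O)NCCC(=O)O)cc1)N1C(=O)C(c2ccc(F)cc2)=N[C@]12CC[C@@H](C(C)(C)C)CC2` gives 430 nM. Compound 2 `CCC[C@H](c1ccc(C(=O)NCc2nn[nH]n2)cc1)N1C(=O)C(c2cc(Cl)cc(Cl)c2)=N[C@]12CC[C@@H](C(C)(C)C)CC2` gives 220 nM in this assay, which lies within the scatter of the number for compound 1. Compound 3 `CC(C)(C)[C@H]1CC[C@]2(CC1)N=C(c1ccc(OC(F)(F)F)cc1)C(=O)N2Cc1ccc(C(=O)NCCC(=O)O)cc1` gives 1900 nM in this assay, a higher number than compound 1 and beyond the scatter; compound 1 thus stands second highest of the three. The step to compound 4 `C[C@H](c1ccc(C(=O)NCCC(=O)O)cc1)N1C(=O)C(c2cccc(Cl)c2F)=N[C@]12CC[C@@H](C(C)(C)C)CC2` is 3-chloro-2-fluorophenyl in place of 4-fluorophenyl on a carbon with a double bond to nitrogen. For the measured compounds named here, no measured pair in the set shows this change on its own, so the expected step from compound 1 to compound 4 is taken to stay within the scatter, with no clear direction, giving an estimated 1.3-fold lower number from compound 1 to compound 4 (0.13 log units; within the scatter). Compound 4 is therefore expected to give about 320 nM in this assay, with a likely range from 110 nM to 950 nM.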

Compound 4, half-maximal inhibitory concentration: 630 nM
Compound 4: the middle estimate sits 2.0-fold (0.29 log units) below what was measured, and the stated range covers the measured number.
By their numbers in this assay, from the lowest: compounds 2, 1 and 4 (each within the scatter of the next, the first and the last beyond it); then compound 3.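

In this assay, for the compounds shown here, placing 3-chloro-2-fluorophenyl in place of 4-fluorophenyl on the carbon with a double bond to nitrogen gives a 1.5-fold higher number from compound 1 to compound 4 (0.17 log units; within the scatter) as the first step that changes one place only. This position therefore accepts this swap, with its added chlorine, without leaving the scatter while the rest of compound 1 stays fixed. Nothing measured here gives a reason for this result.

Going by these compounds, whether an amine or a methoxy group on this phenyl ring would stay within the same range remains open. Also open, on these data alone, is whether the same swap would give a similar step on a core with a different side chain.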